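The compounds below may be only part of what the source reports. "The series", "measured", "known", "first", "only" and "open" are said of these compounds alone.

Measured so far:
- compound 1, `COc1cc(-c2cc(/C=C/C(=O)c3ccc(C)c(C)c3)nc3cc(-c4ccccc4)nn23)cc(OC)c1OC`: 72500 nM
- compound 2, `COc1ccc(C(=O)/C=C/c2cc(-c3ccc(OC)c(OC)c3)n3nc(-c4ccccc4)cc3n2)cc1`: 40000 nM

For the measured compounds named here, in an ADME assay on HEK293 cells (Homo sapiens) for antiproliferative activity, read by MTT assay, with a stated time of 24 h (a higher number here means a weaker inhibitor, a lower number a stronger inhibitor), compound 2 gives 40000 nM, the lowest of the two numbers so far; the nearest is compound 1 with 72500 nM, a gap that sits within the scatter, so no order between the two can be read from these figures.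

The next compound is compound 3, `COc1ccc(/C=C/C(=O)c2cc(-c3ccc(OC)c(OC)c3)n3nc(-c4ccccc4)cc3n2)cc1`, not yet measured in this assay. It differs from compound 2 in one place: (2-(4-methoxyphenyl)ethenyl)carbonyl in place of 2-((4-methoxyphenyl)carbonyl)ethenyl on an aromatic carbon. The atoms are the same; only the arrangement of the chain between the aromatic carbon of the core and the 4-methoxyphenyl group changes.

Going by the values given here, no step between two measured compounds is available to size such a change, and compound 1 offers no help here since it shares the chain arrangement of compound 2. The working expectation is therefore a step from compound 2 to compound 3 of no change at the digits printed from compound 2 to compound 3 (within the scatter), that is, nothing beyond the scatter in either direction. For compound 3 the estimated value in this assay is 40000 nM, with a range from 15000 nM to 110000 nM.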

Compound 3, half-maximal inhibitory concentration: 50700 nM
Compound 3: middle estimate off by 1.3-fold (0.10 log units), on the low side; the range from low to high includes it.
By their numbers in this assay, from the lowest: compounds 2, 3 and 1 (each within the scatter of the next).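

In this assay, for the compounds shown here, placing (2-(4-methoxyphenyl)ethenyl)carbonyl in place of 2-((4-methoxyphenyl)carbonyl)ethenyl on this aromatic carbon gives a 1.3-fold higher number from compound 2 to compound 3 (0.10 log units; within the scatter), the first step that can be sized. For this pair, with the 3,4-dimethoxyphenyl group held constant, the read-out does not separate the chain with its carbonyl joined to the core from the chain with its carbonyl joined to the 4-methoxyphenyl group, so the arrangement of these same atoms has no visible effect here. No supporting measurement bears on this result.

Open, going by these compounds, is whether a chain of another make at this aromatic carbon, such as a saturated two-carbon chain or a longer chain, would give a step beyond the scatter, and whether an amine or a carboxylic acid on the terminal phenyl ring would do so. Also open, on these data alone, is whether the same rearrangement of the chain gives a similar step with the aryl groups of compound 1, since this single pair says nothing about that substitution.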